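Swapping a Small Saturated Ring for an Aromatic One

A few compounds are considered here, and "the series" means these few. Any claim that something is new, unique, unknown or untested is made for them only; others in the source may bear on it.

Compound 1 `COc1cccc(-n2cc3nc(-c4cccnc4C)n(C[C@H]4CCCN(CC5CCO5)C4)c(=O)c3n2)c1` is the reference point of this small set. In an assay on HEK293 cells for displacement of a labelled ligand from growth hormone secretagogue receptor type 1 (Homo sapiens), with a stated time of 60 min (a higher number here means a weaker inhibitor, a lower number a stronger inhibitor), compound 1 gives 23 nM, the lowest number among the three measured compounds. Compound 3 `COc1cccc(-n2cc3nc(-c4cccnc4C)n(C[C@H]4CCCN(CC5CCOC5)C4)c(=O)c3n2)c1` gives 60 nM, and compound 2 `Cc1ncccc1-c1nc2cn(-c3ccccc3)nc2c(=O)n1C[C@H]1CCCN(C[C@H]2CCCO2)C1` gives 190 nM; compound 2 differs from compound 1 in two places at once, so its value is simply read on its own.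

Compound 4 `COc1cccc(-n2cc3nc(-c4cccnc4C)n(C[C@H]4CCCN(Cc5ccco5)C4)c(=O)c3n2)c1` differs from compound 1 in one place: furan-2-yl in place of oxetan-2-yl on a saturated chain carbon bound to an amine nitrogen in a ring

For the measured compounds named here, the only measured step that touches the same place is a 2.6-fold higher number from compound 1 to compound 3 (0.42 log units; beyond the scatter), where a saturated five-membered ring with one oxygen replaced the oxetan-2-yl group. Compound 4 instead carries an aromatic five-membered ring with one oxygen at that position. Going by the values given here, no measured pair shows the effect of moving from a saturated to an aromatic ring here, so the expectation leans on compound 3 alone and is held loosely.

Compound 4 is expected to show a 2.2-fold higher number from compound 1 to compound 4 (0.34 log units; beyond the scatter), a modest weakening of the same order as compound 3, with an estimated value of 50 nM and a plausible range from 18 nM to 140 nM.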

Compound 4, half-maximal inhibitory concentration: 2.7 nM
The estimate for compound 4 lay 19-fold (1.27 log units) above the measured number; measured number outside the range, below it.
By their numbers in this assay, from the lowest: compound 4; then compound 1; then compound 3; then compound 2.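

This position responds in both directions: oxolan-3-yl raised the number, but furan-2-yl gives an 8.5-fold lower number from compound 1 to compound 4 (0.93 log units; beyond the scatter) on the saturated chain carbon bound to the ring amine nitrogen. The contrast between the two five-membered rings is wider still, with a 22-fold lower number from compound 3 to compound 4 (1.35 log units; beyond the scatter) for a change that also moves the ring's point of attachment, so aromaticity and attachment cannot be separated in this step. No evidence here explains why furan-2-yl gives the lowest number of the set.

Going by these compounds, it remains open whether this gain belongs to furan-2-yl alone or extends to aromatic rings more widely. Thiophen-2-yl, phenyl or pyridinyl at this same place would help to settle that, and furan-3-yl would show how much the point of attachment matters.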